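Swapping an aromatic ring for a saturated one on the shared core

This account rests on a few compounds, and the source may have more. Where it says the series, first, only, none or still open, it means among the compounds named here.

Of the compounds shown here, three sharing one core have been measured in a functional assay on HepG2 cells (Homo sapiens) for antiproliferative activity, read by MTT assay, with a stated time of 48 h; on this read-out lower numbers stand for stronger inhibition and higher numbers for weaker inhibition. Compound 1 `O=C(Nc1cccc(Cl)c1)Nc1cccc(CNc2nccnc2Cl)c1` gives 9140 nM. Compound 2 `CC(C)(C)c1ccc(NC(=O)Nc2cccc(CNc3nccnc3Cl)c2)cc1` gives 7550 nM, and compound 3 `CS(=O)(=O)c1ccc(NC(=O)Nc2cccc(CNc3nccnc3Cl)c2)cc1` gives 15100 nM. On these numbers compound 1 stands second highest of three; its nearest neighbour is compound 2, and its furthest is compound 3, yet both gaps are within the usual scatter, so no ordering among the three can be claimed.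

Among the measured compounds shown here, the only single-point step recorded so far is a 2.0-fold higher number from compound 2 to compound 3 (0.30 log units; within the scatter), a change on an aromatic carbon of a side ring, not on the amide-type nitrogen itself.

Compound 4 `O=C(Nc1cccc(CNc2nccnc2Cl)c1)NC1CCCCC1` differs from compound 1 by cyclohexyl in place of 3-chlorophenyl on an amide-type nitrogen. For the measured compounds named here, no measured step touches this kind of change: the aromatic ring with its chlorine is replaced by a six-membered non-aromatic ring of carbon only. The recorded step, although it is within the scatter, suggests that changes on this side of the core have so far moved this assay little.

Compound 4 is therefore expected to sit near the others, with a 1.3-fold higher number from compound 1 to compound 4 (0.12 log units; within the scatter) as the estimated step. The estimate for compound 4 is 12000 nM, expected between 4000 nM and 40000 nM.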

Compound 4, half-maximal inhibitory concentration: > 40000 nM
Compound 4 gave a limit, no number; the forecaster's own chance of this, stated with the estimate: 15%; middle value at least 3.3-fold (0.52 log units) away from the limit.
By their numbers in this assay, from the lowest: compounds 2, 1 and 3 (each within the scatter of the next). At a limit, above all of these: compound 4.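

Among the compounds shown here, at the amide-type nitrogen, cyclohexyl in place of 3-chlorophenyl gives the first step beyond the scatter in this assay, an at least 4.3-fold higher number from compound 1 to compound 4 (0.64 log units; beyond the scatter). Compound 4 gives > 40000 nM, which is a limit of the assay and not a number: the limit of > 40000 nM in this assay, at which 1 of the 4 values shown sits. For the compounds shown here, the one earlier step, a 2.0-fold higher number from compound 2 to compound 3 (0.30 log units; within the scatter), exchanged one group for another on an aromatic carbon and kept the aromatic ring in place, whereas this change replaces the ring itself, and it shows that the group on this nitrogen can matter strongly for the read-out even though the earlier compounds lay within the scatter of one another.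

The compounds shown leave open whether the weaker inhibition follows from losing the aromatic ring or from losing its chlorine, and plain phenyl on the same nitrogen would separate these two possibilities, as would a chlorine carried on the cyclohexyl ring. They also leave open whether any saturated ring can work here, for instance a smaller cyclopentyl or a piperidine ring with its ring nitrogen.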